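A few compounds are considered here, and "the series" means these few. Any claim that something is new, unique, unknown or untested is made for them only; others in the source may bear on it.

Measured compounds:
- compound 1, `Nc1cccc(-c2cn3c(-c4ccc(Cl)cc4)csc3n2)c1`, 11000 nM
- compound 2, `C=C(Br)C(=O)Nc1cccc(-c2cn3nc(Cc4cccc(OC)c4)sc3n2)c1`, 1100 nM

Both compounds were tested in a functional assay on FM3A cells (Mus musculus) for inhibition, read by cell counting, with a stated time of 2 days; a lower number here means a stronger inhibitor, a higher number a weaker inhibitor. Compound 1 gives 11000 nM in this assay, while compound 2 gives 1100 nM. Of the two numbers, compound 2 stands at the lower end, and its gap to compound 1 is beyond the usual scatter of repeated measurements, so compound 2 is the stronger inhibitor of the pair. For the measured compounds named here, the two compounds differ in several places at once, and no single structural step connects them. No cause for the gap can be drawn from these two values alone.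

Compound 3, `C=C(Br)C(=O)Nc1cccc(-c2cn3nc(Cc4ccccc4)sc3n2)c1`, has not yet been measured. It differs from compound 2 in one place only: hydrogen in place of methoxy on an aromatic carbon. Going by the values given here, this is a small change at the edge of the molecule, and no step between measured compounds shows what removing a methoxy does here. The expectation is therefore a step from compound 2 to compound 3 in this assay that stays within the scatter, or at most a slight weakening, a 1.5-fold higher number from compound 2 to compound 3 (0.16 log units; within the scatter). Compound 3 is estimated to give 1600 nM in this assay, most likely between 600 nM and 4500 nM.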

Compound 3, half-maximal inhibitory concentration: 3000 nM
The estimate for compound 3 lay 1.9-fold (0.27 log units) below the measured number; measured number inside the range.
By their numbers in this assay, from the lowest: compound 2; then compound 3; then compound 1.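

Hydrogen in place of methoxy on the aromatic carbon gives a 2.7-fold higher number from compound 2 to compound 3 (0.44 log units; beyond the scatter) in this assay and provides the first comparison here in which only one place changes. Although modest, this step lies beyond the usual scatter of repeated measurements, so the group at this position of the six-membered aromatic ring has a measurable bearing on the result, with the methoxy-bearing compound 2 the stronger inhibitor of this pair. Nothing available here explains why the loss of the methoxy weakens inhibition, so this remains an observed difference without an established cause.

This single change cannot show whether the benefit is specific to methoxy or would also appear with another group at this position, such as a hydroxyl, a fluorine atom, an ethoxy or an amine. It also leaves open whether a methoxy placed elsewhere on the ring would give a similar number, and whether the same step would hold on a compound that differs elsewhere in its structure.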